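The compounds below may be only part of what the source reports. "The series", "measured", "known", "first", "only" and "open" are said of these compounds alone.

The three measured compounds and their readings in an assay on microsomes for inhibition of Amine oxidase [flavin-containing] A (Homo sapiens), read by fluorescence and spectrophotometry, with a stated time of 20 min; on this read-out lower numbers stand for stronger inhibition and higher numbers for weaker inhibition:

Compound 1 `Cn1c(=O)c2c(nc(SCCc3ccc(Br)cc3)n2C)n(C)c1=O` gives 108000 nM
Compound 2 `Cn1c(=O)c2c(nc(SCCc3ccc(F)cc3)n2C)n(C)c1=O` gives 14700 nM
Compound 3 `Cc1ccc(CCSc2nc3c(c(=O)n(C)c(=O)n3C)n2C)cc1` gives 125000 nM

Compound 3 shows the highest number of the three, though its gap to compound 1 is within the scatter, as a 1.2-fold higher number from compound 1 to compound 3 (0.06 log units; within the scatter) shows. Among the measured compounds shown here, only compound 2 stands clearly apart: an 8.5-fold higher number from compound 2 to compound 3 (0.93 log units; beyond the scatter) and a 7.3-fold lower number from compound 1 to compound 2 (0.87 log units; beyond the scatter) are the sole steps here that go beyond the scatter, and both involve the fluoro compound.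

Compound 4 `COc1ccc(CCSc2nc3c(c(=O)n(C)c(=O)n3C)n2C)cc1` differs from compound 3 by methoxy in place of methyl on an aromatic carbon. For the measured compounds named here, no measured pair trades methyl for methoxy, so the three steps bear on it only indirectly: they show that swapping one small group for another at this position has moved the number little between bromo and methyl, and modestly only when fluoro was involved. On that footing a change within the scatter, or at most a small one, is expected, and the estimate for compound 4 in this assay is 80000 nM, within a range from 25000 nM to 250000 nM, which means an expected step of a 1.6-fold lower number from compound 3 to compound 4 (0.19 log units; within the scatter).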

Compound 4, half-maximal inhibitory concentration: 168000 nM
Compound 4: middle estimate off by 2.1-fold (0.32 log units), on the low side; measured number inside the range.
By their numbers in this assay, from the lowest: compound 2; then compounds 1, 3 and 4 (each within the scatter of the next).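

In this assay, the change from 4-methylphenyl to 4-methoxyphenyl gives a 1.3-fold higher number from compound 3 to compound 4 (0.13 log units; within the scatter), so at this place, para to a large group, the larger methoxy group, which adds an oxygen and a hydrogen-bond acceptor, cannot be told apart from methyl. The comparison with bromo, a 1.6-fold higher number from compound 1 to compound 4 (0.19 log units; within the scatter), points the same way and places methoxy as a third group in the cluster that earlier held only bromo and methyl. Fluoro remains the one group among these four that stands apart, and the step to methoxy, an 11-fold higher number from compound 2 to compound 4 (1.06 log units; beyond the scatter), is the only one in the set that is printed as large, widening the contrast that the earlier steps from the fluoro compound had shown only as modest.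

Nothing on hand gives a reason why the fluoro compound separates from the other three. On these data alone, whether chloro, a hydroxyl, an amine or a carboxylic acid at this place would read with the fluoro compound or with the cluster remains open, as does the effect of a longer chain on the sulfur.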